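A few compounds are considered here, and "the series" means these few. Any claim that something is new, unique, unknown or untested is made for them only; others in the source may bear on it.

Compound 1 `O=C(CCCNC(=O)c1cc(C(F)(F)F)cc(C(F)(F)F)c1)Nc1ccc(Cl)cc1`: 0%
Compound 2 `O=C(Nc1cc(C(F)(F)F)cc(C(F)(F)F)c1)C1CCN(C(=O)c2ccc(Cl)cc2)CC1`: 30%
Compound 3 `FC(F)(F)c1cc(CNCCCNc2ccc(Cl)cc2)cc(C(F)(F)F)c1`: 0%

All three were tested in a functional assay on PC-3 cells (Homo sapiens) for inhibition, read by WST assay, tested at 10 uM; on this read-out higher numbers stand for a stronger effect at the one concentration tested and lower numbers for a weaker effect. Compound 1 stands level with compound 3 at the digits shown, the two together the lowest of the three numbers, and the gap between them lies within the usual scatter. Compound 2 lies furthest from compound 1, higher by a step beyond the scatter.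

Compound 4 `O=C(NCCCOc1ccc(Cl)cc1)c1cc(C(F)(F)F)cc(C(F)(F)F)c1` has not yet been measured in this assay. Compared with compound 1 it carries 4-chlorophenoxy in place of (4-chlorophenyl)carbamoyl on a saturated chain carbon, three bonds along the chain from an amide-type nitrogen. The shared core of compound 1 is kept. No step is expected beyond the scatter, since compound 1 gives 0% and compound 3, which also lacks this carbamoyl group, gives 0%. The expected step is a number 5 percentage points higher from compound 1 to compound 4 (within the scatter). Compound 4 is therefore estimated at 5%, within a range from -10% to 25%.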

Compound 4, a percentage reported as inhibition, at one concentration (the size of the read-out at that concentration, not a potency): 0%
Beside the measured number, compound 4's estimate is 5 percentage points above it, within the range that was stated.
By their numbers in this assay, from the lowest: compounds 1, 3 and 4 (each within the scatter of the next); then compound 2.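

In this assay, 4-chlorophenoxy in place of (4-chlorophenyl)carbamoyl on a saturated chain carbon, three bonds along the chain from an amide-type nitrogen, gives no change at the digits printed from compound 1 to compound 4 (within the scatter). Within the data shown here, this is the first single-place step here, and exchanging a group with a hydrogen-bond donor for one with none brings no gain from the 0% of compound 1, which could hardly show a loss. No measurement at hand explains this result. Going by these compounds, whether an amine, a carboxylic acid or a longer chain at this place would raise the number stays open.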